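Swapping the Triazole Substituent: Expected Potency of Compound 4

A few compounds are considered here, and "the series" means these few. Any claim that something is new, unique, unknown or untested is made for them only; others in the source may bear on it.

Compound 2 `CCOC(=O)C1=Cc2ccccc2OC1(OCc1cn(CC(=O)Nc2ccc(OC)cc2)nn1)C(F)(F)F` carries, on the ring nitrogen of its five-membered ring with three nitrogens, a ((4-methoxyphenyl)carbamoyl)methyl group; compound 4 `CCOC(=O)C1=Cc2ccccc2OC1(OCc1cn(-c2cccc(C(F)(F)F)c2)nn1)C(F)(F)F` keeps the same core. In a functional assay on DU-145 cells (Homo sapiens) for inhibition, read by MTT assay, with a stated time of 24 h (on this read-out higher numbers stand for weaker inhibition and lower numbers for stronger inhibition), compound 2 gives 32700 nM. Compound 3 `CCOC(=O)C1=Cc2ccccc2OC1(OCc1cc(-c2ccc(Cl)cc2)no1)C(F)(F)F` gives 18200 nM in this assay, and this value and that of compound 2 lie within the usual scatter of each other. Compound 1 `CCOC(=O)C1=Cc2ccccc2OC1(OCc1cc(-c2ccc(F)cc2F)no1)C(F)(F)F` gives only a limit in this assay, namely > 150000 nM, as recorded in the limit of > 150000 nM in this assay, at which 1 of the 3 values shown sits. The change from compound 2 to compound 4 is 3-(trifluoromethyl)phenyl in place of ((4-methoxyphenyl)carbamoyl)methyl on an aromatic nitrogen. Going by the values given here, the only measured single step, an at least 8.2-fold lower number from compound 1 to compound 3 (0.91 log units; beyond the scatter), concerns a different five-membered ring and a different pair of groups, so it bears only loosely on the present change. Among the compounds with values here, with no measured step that matches an exchange on the ring nitrogen, the expectation is a number close to that of compound 2, so the step of a 1.2-fold lower number from compound 2 to compound 4 (0.07 log units; within the scatter) is expected to stay within the scatter. Compound 4 is therefore estimated at 28000 nM, within a range from 8000 nM to 90000 nM.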

Compound 4, half-maximal inhibitory concentration: > 150000 nM
Compound 4: a limit, no number (the forecaster's own chance of this, stated with the estimate: 15%); middle value at least 5.3-fold (0.72 log units) away from the limit.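

On the ring nitrogen of the five-membered ring with three nitrogens, the choice of group proved to matter: in this assay, 3-(trifluoromethyl)phenyl in place of ((4-methoxyphenyl)carbamoyl)methyl gives an at least 4.5-fold higher number from compound 2 to compound 4 (0.66 log units; beyond the scatter). Going by these compounds alone, a higher number here means weaker inhibition, so with the shared core unchanged, this exchange loses inhibition, and it is the first measured step at this position. The value of compound 4 is a limit and not a number: the limit of > 150000 nM in this assay, at which 2 of the 4 values shown sit.

The exchange replaces the whole group, so the compounds shown do not separate the part played by the amide hydrogen and carbonyl from that of the methoxy group or the trifluoromethyl group. On these data alone, how an amine or a carboxylic acid at the end of a longer chain on this ring nitrogen would read also remains open.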